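Reversing the Amine-to-Alcohol Switch at the Chain Terminus

A few compounds are considered here, and "the series" means these few. Any claim that something is new, unique, unknown or untested is made for them only; others in the source may bear on it.

Measured compounds:
Compound 1, `CCCCNc1nc(N)nc(C)c1CCCCO`, gives 1310 nM in an assay on HEK293 cells for agonist activity at Toll-like receptor 8 (Homo sapiens), read by spectrophotometry; a higher number here means that more compound is needed for the effect, a lower number that less compound is needed.
Compound 2, `CCCCNc1nc(N)nc(C)c1CCCN1CCCCC1`, gives 133 nM in this assay.
Compound 3, `CCCCNc1nc(N)nc(C)c1C#CCN1CCCCC1`, gives 3790 nM in this assay.

Compound 2 has the lowest number of the three in this assay, with compound 1 the nearest and compound 3 the furthest of the measured compounds, both separated from it by steps beyond the scatter.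

Compound 4, `CCCCNc1nc(N)nc(C)c1CCCC(C)(C)O`, has not yet been measured in this assay. It differs from compound 2 in one place: 1-hydroxy-1-methylethyl in place of piperidin-1-yl on a saturated chain carbon, three bonds along the chain from an aromatic carbon. Among the compounds with values here, the one measured step that bears on this change is the step from compound 1 to compound 2, which gave a 9.8-fold lower number from compound 1 to compound 2 (0.99 log units; beyond the scatter); there a chain ending in a hydroxyl group was exchanged for the piperidin-1-yl group. Compound 4 returns a hydroxyl-bearing terminus at the same chain position, so the present account expects that step to be largely undone in this assay: a higher number for compound 4 than for compound 2, with an estimated step of an 11-fold higher number from compound 2 to compound 4 (1.05 log units; beyond the scatter). The expected value for compound 4 is 1500 nM, within the estimated range 500 nM to 5000 nM.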

Compound 4, half-maximal effective concentration: 1220 nM
The estimate for compound 4 lay 1.2-fold (0.09 log units) above the measured number; the range from low to high includes it.
By their numbers in this assay, from the lowest: compound 2; then compounds 4 and 1 (each within the scatter of the next); then compound 3.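

Two different hydroxyl-bearing ends have now been compared on the saturated chain carbon, three bonds along the chain from an aromatic carbon, and in this assay the change from hydroxymethyl to 1-hydroxy-1-methylethyl gives a 1.1-fold lower number from compound 1 to compound 4 (0.03 log units; within the scatter). The lower number of compound 2 therefore holds against both of these ends, with a 9.2-fold higher number from compound 2 to compound 4 (0.96 log units; beyond the scatter) showing on a second hydroxyl-bearing end what the single earlier comparison had shown on the first. Nothing available here gives a reason for either step.

The compounds shown leave open whether the lower number belongs to piperidin-1-yl itself or would also appear with another amine at this place, such as dimethylamino or morpholin-4-yl. They also leave open how a carboxylic acid at this place, or a longer chain carrying piperidin-1-yl, would read in this assay.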